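A few compounds are considered here, and "the series" means these few. Any claim that something is new, unique, unknown or untested is made for them only; others in the source may bear on it.

Measured in a functional assay on DU-145 cells (Homo sapiens) for inhibition; a higher number here means a weaker inhibitor, a lower number a stronger inhibitor:
- compound 1, `Oc1ccccc1-c1cc(-c2ccc(F)cc2)cc(-c2ccccc2O)n1`, gives > 50000 nM, which is a limit of the assay.
- compound 2, `Oc1ccc(-c2cc(-c3cccc(F)c3)cc(-c3ccccc3O)n2)cc1`, gives > 50000 nM, which is a limit of the assay.
- compound 3, `Oc1ccc(-c2cc(-c3ccc(F)cc3)cc(-c3ccccc3O)n2)cc1`, gives > 50000 nM, which is a limit of the assay.

Compound 3 thus stands only at a limit in this assay, and the two further values shown are limits as well, as the limit of > 50000 nM in this assay, at which 3 of the 3 values shown sit, records. The two measured steps that lead to compound 3, a step that the two limits leave unreadable from compound 1 to compound 3 and a step that the two limits leave unreadable from compound 2 to compound 3, cannot be read in size because the limit of > 50000 nM in this assay, at which 3 of the 3 values shown sit, holds all three values at the same limit.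

Compound 4, `Oc1ccc(-c2cc(-c3ccc(F)cc3)cc(-c3cccc(O)c3)n2)cc1`, differs from compound 3 in one place: 3-hydroxyphenyl in place of 2-hydroxyphenyl on an aromatic carbon. Of the measured steps, only the change of a hydroxyphenyl group from compound 1 to compound 3 resembles this one, and its size is not readable. With no readable step to build on, and every measured value at the limit, the expectation is that compound 4 also stays at the limit. The step that the limit leaves unreadable from compound 3 to compound 4 is therefore expected to be none beyond the scatter. Compound 4 is estimated at 70000 nM, within the range 20000 nM to 250000 nM.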

Compound 4, half-maximal inhibitory concentration: 15200 nM
The estimate for compound 4 lay 4.6-fold (0.66 log units) above the measured number, and the stated range ends above it.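

In this assay, 3-hydroxyphenyl in place of 2-hydroxyphenyl, on the aromatic carbon next to the ring nitrogen, gives the first readable step among these compounds, an at least 3.2-fold lower number from compound 3 to compound 4 (0.51 log units; beyond the scatter). The two groups have the same heavy atoms and the same counts of hydrogen-bond donors and acceptors, so this position distinguishes between two hydroxyphenyl isomers, and compound 4 alone gives a number rather than a limit. The other steps still cannot be read, because their values rest on a single limit: the limit of > 50000 nM in this assay, at which 3 of the 4 values shown sit.

For the compounds shown here, only this one pair shows the change, so it remains open whether the step would hold without the 4-hydroxyphenyl and 4-fluorophenyl groups that compound 3 and compound 4 share. As far as these compounds go, it is also open whether an amine or a carboxylic acid on this phenyl ring, in place of the hydroxyl, would give a similar value.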